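Ortho halogen swap on a thiosemicarbazone scaffold

The source may report more compounds than this note shows. Statements on the series, on what has been measured and on what is new or still open speak of the compounds shown alone.

Compound 1, `C/C(=N/NC(=S)Nc1ccccc1Cl)c1ccccn1`, in a functional assay on U-87MG ATCC cells (Homo sapiens) for cytotoxicity, read by MTT assay, with a stated time of 48 h (on this read-out lower numbers stand for stronger inhibition and higher numbers for weaker inhibition), gives 2.6 nM.
Compound 2, `C/C(=N/NC(=S)Nc1cccc(I)c1)c1ccccn1`, gives 84 nM.
Compound 3, `C/C(=N\NC(=S)Nc1ccccc1Cl)c1ccccn1`, gives 2.6 nM.

Compound 3 sits level with compound 1 at the digits shown, and the two together give the lowest numbers of the three; compound 2 stands furthest from compound 3, with a markedly higher number. Among the compounds with values here, the only step measured between compounds that differ in one place runs no change at the digits printed from compound 1 to compound 3 (within the scatter), and this lack of change rests on (the fact that compounds 1 and 3 differ only in the configuration as drawn).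

Compound 4, `C/C(=N\NC(=S)Nc1ccccc1I)c1ccccn1`, is not yet measured. It differs from compound 3 by iodo in place of chloro on an aromatic carbon. Within the data shown here, no measured step bears directly on this change: the single measured step concerns configuration only, and compound 2 differs from compound 3 both in the halogen and in where it sits on the ring, so the gap between them cannot be pinned to either part. Among the measured compounds shown here, the values of compounds 2 and 3 show only that a compound with iodo elsewhere on the ring gave a higher number.

For the measured compounds named here, because the one measured step of no change at the digits printed from compound 1 to compound 3 (within the scatter) carries no information on the halogen, the expectation for compound 4 is wide. Compound 4 is therefore expected to give a modestly higher number, with the step from compound 3 estimated at a 2.3-fold higher number from compound 3 to compound 4 (0.36 log units; beyond the scatter). For compound 4 the estimate in this assay is 6 nM, within a range from 1.5 nM to 40 nM.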

Compound 4, half-maximal inhibitory concentration: 6.1 nM
Compound 4: middle estimate off by 1.0-fold (0.01 log units), on the low side; the measured number falls inside the stated range.
By their numbers in this assay, from the lowest: compounds 1 and 3 (each within the scatter of the next); then compound 4; then compound 2.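

In this assay, within the data shown here, iodo in place of chloro on an aromatic carbon, ortho to a large group, gives a 2.3-fold higher number from compound 3 to compound 4 (0.37 log units; beyond the scatter) and is the first change to isolate the halogen at this position. Among these compounds, earlier, the only iodo compound, compound 2, differed from compound 3 in both the halogen and its place on the ring, so the size of a halogen swap at this position could not be read. The step now shows that this position takes iodo with a modest rise in the number, and nothing in the information given accounts for the size of this step.

Still open, from the compounds shown here alone, is whether bromo, fluoro, or a group of another kind such as methoxy or an amine would be tolerated at this position to the same degree as iodo. Also open is whether the configuration as drawn is as silent with iodo as with chloro, where the reading is no change at the digits printed from compound 1 to compound 3 (within the scatter) and no matching pair of iodo compounds is shown, and how the gap to compound 2 divides between the halogen and its place on the ring.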